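Pyrrolopyrimidine ribosides in the fibroblast viability assay

The compounds below may be only part of what the source reports. "The series", "measured", "known", "first", "only" and "open" are said of these compounds alone.

Measured compounds:
compound 1 `COc1ncnc2c1c(-c1ccoc1)cn2[C@@H]1O[C@H](CO)[C@@H](O)[C@H]1O`: 28800 nM
compound 2 `Cc1ncnc2c1c(-c1ccoc1)cn2[C@@H]1O[C@H](CO)[C@@H](O)[C@H]1O`: 89200 nM
compound 3 `COc1nc(N)nc2c1c(-c1ccoc1)cn2[C@@H]1O[C@H](CO)[C@@H](O)[C@H]1O`: > 100000 nM

In an ADME assay on BJ cells (Homo sapiens), read by MTT assay, with a stated time of 72 h (a higher number here means a weaker inhibitor, a lower number a stronger inhibitor), compound 1 gives 28800 nM, the lowest of the two numbers in the series. Compound 2 sits higher, with a 3.1-fold higher number from compound 1 to compound 2 (0.49 log units; beyond the scatter). For compound 3 only a limit of the assay is known, > 100000 nM; this is the limit of > 100000 nM in this assay, at which 1 of the 3 values shown sits. From compound 1 to compound 3 the step is an at least 3.4-fold higher number from compound 1 to compound 3 (0.54 log units; beyond the scatter), described as a limit rather than a number.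

Compound 4 `C#Cc1cn([C@@H]2O[C@H](CO)[C@@H](O)[C@H]2O)c2ncnc(OC)c12` has not yet been measured in this assay. It differs from compound 1 in one place: ethynyl in place of furan-3-yl on an aromatic carbon. Neither measured step touches this position; both concern substituents on the six-membered ring of the shared core, and both made the number higher by a modest amount. Among the compounds with values here, no measured step therefore bears directly on the change to compound 4, and no direction can be drawn from the data. The expectation is for a number close to that of compound 1, with a wide spread, so the step from compound 1 is estimated as a 1.4-fold higher number from compound 1 to compound 4 (0.14 log units; within the scatter). For compound 4 the estimate in this assay is 40000 nM, within a range of 12000 nM to 150000 nM.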

Compound 4, half-maximal inhibitory concentration: 98400 nM
For compound 4 the middle estimate is 2.5-fold (0.39 log units) below the measured one; the range from low to high includes it.
By their numbers in this assay, from the lowest: compound 1; then compounds 2 and 4 (each within the scatter of the next). At a limit, above all of these: compound 3.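

The position on the five-membered aromatic ring, two ring bonds from the ring nitrogen, now responds to change as well, so the number in this assay does not depend only on the substituents on the six-membered ring of the shared core, which compounds 2 and 3 varied. Exchanging a five-membered aromatic ring for a group with no ring and a triple bond gives a 3.4-fold higher number from compound 1 to compound 4 (0.53 log units; beyond the scatter), so furan-3-yl carries the lower number of the two groups at this position, although this single pair cannot separate the loss of the ring from the gain of the triple bond. Compound 4 gives a number rather than a limit, and compound 3 remains the only compound at a limit: the limit of > 100000 nM in this assay, at which 1 of the 4 values shown sits.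

Open, on these data alone, is whether a thiophen-3-yl or phenyl ring at this position would keep the number of compound 1, and whether a cyclopropyl ring or a plain ethyl chain would follow compound 4. Also open, as far as these compounds go, is how an aminomethyl group or a carboxylic acid would read here, and whether the ethynyl step holds with methyl on the six-membered ring.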